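The source may report more compounds than this note shows. Statements on the series, on what has been measured and on what is new or still open speak of the compounds shown alone.

Compound 1 `O=C(O)C12CC(CN3CCC[C@H](O[C@H](CO)c4cc(Cl)cc(Cl)c4)[C@@H]3c3ccccc3)(C1)C2` gives 12000 nM in an assay on isolated protein for activation of cGMP-dependent protein kinase 1 (Homo sapiens), read by ADP-Glo, with stated times of 30 min and 2 h, in the presence of a further agent that is not named here; a higher number here means that more compound is needed for the effect, a lower number that less compound is needed; compound 2 `COC(=O)c1ccc(CN2CCC[C@H](O[C@H](CO)c3cc(Cl)cc(Cl)c3)[C@@H]2c2ccccc2)c(C)c1` gives 900 nM; compound 3 `Cc1nc(C(=O)O)ccc1CN1CCC[C@H](O[C@H](CO)c2cc(Cl)cc(Cl)c2)[C@@H]1c1ccccc1` gives 370 nM.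

Compound 3 thus has the lowest number of the three, below compound 2 by a 2.4-fold lower number from compound 2 to compound 3 (0.39 log units; beyond the scatter) and below compound 1 by a 32-fold lower number from compound 1 to compound 3 (1.51 log units; beyond the scatter). Compound 4 `Cc1cc(C(=O)O)ccc1C(=O)N1CCC[C@H](O[C@H](CO)c2cc(Cl)cc(Cl)c2)[C@@H]1c1ccccc1` differs from compound 3 in one place: a group of 12 heavy atoms (9 carbon, 3 oxygen; one six-membered aromatic ring of carbon only) in place of a group of 11 heavy atoms (8 carbon, 1 nitrogen, 2 oxygen; one six-membered aromatic ring with 1 hetero atom), on an amine nitrogen in a ring. Going by the values given here, no measured step swaps the saturated carbon on the ring nitrogen for a carbonyl, so the steps among compounds 1, 2 and 3 bear on this change only loosely; they show that altering the group on this nitrogen can move the number a great deal. Compound 4 is expected to give a higher number than compound 3, a 3.2-fold higher number from compound 3 to compound 4 (0.51 log units; beyond the scatter). The estimate for compound 4 is 1200 nM, ranging from 250 nM to 6000 nM.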

Compound 4, half-maximal effective concentration: > 200000 nM
Compound 4: only a limit was reported (the forecaster's own chance of this, stated with the estimate: 10%); middle value at least 160-fold (2.22 log units) away from the limit.
By their numbers in this assay, from the lowest: compound 3; then compound 2; then compound 1. At a limit, above all of these: compound 4.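

In this assay compound 4 gives only a limit of the assay (> 200000 nM). With a carbonyl on the amine nitrogen in a ring, in place of a saturated carbon, every step to compound 4 is large (an at least 540-fold higher number from compound 3 to compound 4 (2.73 log units; beyond the scatter); an at least 220-fold higher number from compound 2 to compound 4 (2.34 log units; beyond the scatter); an at least 16-fold higher number from compound 1 to compound 4 (1.22 log units; beyond the scatter)). Even compound 1, the highest number among the compounds with a saturated carbon here, is passed.

Each of these steps also alters the rest of the group, so the share of the carbonyl alone cannot be read. Going by these compounds, whether a sulfonyl group or a longer carbon chain on this nitrogen would keep the number low stays open.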